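Phenyl for hydrogen on an ether chain, second time

A few compounds are considered here, and "the series" means these few. Any claim that something is new, unique, unknown or untested is made for them only; others in the source may bear on it.

Measured compounds:
Compound 1 `COCNc1n[n+]([O-])c2ccccc2[n+]1[O-]`, 6670 nM
Compound 2 `[O-][n+]1nc(NCOCc2ccccc2)[n+]([O-])c2ccccc21`, 20100 nM
Compound 3 `CCOCNc1n[n+]([O-])c2ccccc2[n+]1[O-]`, 27100 nM

All three were tested in a functional assay on SMMC-7721 cells (Homo sapiens) for cytotoxicity, read by MTT assay, with a stated time of 72 h; a lower number here means a stronger inhibitor, a higher number a weaker inhibitor. Compound 2 differs from compound 1 by phenyl in place of hydrogen on a saturated chain carbon bound to an oxygen on a saturated carbon, and that change made a step of a 3.0-fold higher number from compound 1 to compound 2 (0.48 log units; beyond the scatter). Compound 3 differs from compound 1 by methyl in place of hydrogen on a saturated chain carbon bound to an oxygen on a saturated carbon, giving a 4.1-fold higher number from compound 1 to compound 3 (0.61 log units; beyond the scatter). Compound 2 and compound 3 sit close together, with a 1.3-fold higher number from compound 2 to compound 3 (0.13 log units; within the scatter).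

Compound 4 `CC(OCNc1n[n+]([O-])c2ccccc2[n+]1[O-])c1ccccc1` has not yet been measured. It differs from compound 3 by phenyl in place of hydrogen on a saturated chain carbon bound to an oxygen on a saturated carbon and a saturated chain carbon. This is the same kind of change as that from compound 1 to compound 2, but not the same: in compound 4 the carbon carrying the new phenyl is bound to an oxygen on a saturated carbon and a saturated chain carbon, whereas in compound 2 it is bound only to an oxygen on a saturated carbon. Because the earlier step of a 3.0-fold higher number from compound 1 to compound 2 (0.48 log units; beyond the scatter) was modest and weakening, a weakening step of similar size is expected here, a 2.4-fold higher number from compound 3 to compound 4 (0.38 log units; beyond the scatter). Compound 4 is therefore estimated at 65000 nM, most likely between 25000 nM and 150000 nM.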

Compound 4, half-maximal inhibitory concentration: 12900 nM
For compound 4 the middle estimate is 5.0-fold (0.70 log units) above the measured one; the measured number lies below the stated range.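

In this assay, phenyl in place of hydrogen gave a 2.1-fold lower number from compound 3 to compound 4 (0.32 log units; beyond the scatter), so the earlier step carries over to this core in neither size nor direction: the same change on two cores in this assay, a 3.0-fold higher number (0.48 log units; beyond the scatter) from compound 1 to compound 2 and a 2.1-fold lower number (0.32 log units; beyond the scatter) from compound 3 to compound 4, 6.3-fold (0.80 log units) apart, beyond the scatter of two such steps Methyl in place of hydrogen gave a 1.6-fold lower number from compound 2 to compound 4 (0.19 log units; within the scatter), and this step also fails to match its earlier counterpart: the same change on two cores in this assay, a 4.1-fold higher number (0.61 log units; beyond the scatter) from compound 1 to compound 3 and a 1.6-fold lower number (0.19 log units; within the scatter) from compound 2 to compound 4, 6.3-fold (0.80 log units) apart, beyond the scatter of two such steps These two comparisons show that, among these four compounds, the result of each change depends on the compound that receives it, but they do not show why, and they cannot predict the same change on another core.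

The compounds shown carry only hydrogen, methyl or phenyl on the two chain carbons that were changed, so it remains open whether a longer chain or an amine at the same place would follow the pattern of compound 2 or that of compound 4. All the values also come from a single cell assay, which leaves open whether the same reversal would appear in another cell line.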